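Ethenyl-linked amide in place of the benzamide of compound 2

This account rests on a few compounds, and the source may have more. Where it says the series, first, only, none or still open, it means among the compounds named here.

Measured so far in a functional assay on PC-3 cells (Homo sapiens) for antiproliferative activity, read by MTT assay, with a stated time of 48 h; on this read-out lower numbers stand for stronger inhibition and higher numbers for weaker inhibition:
compound 1, `O=C(/C=C/c1ccc([N+](=O)[O-])cc1)Nc1cc(Sc2ncn[nH]2)c(O)c2ccccc12`: > 100000 nM
compound 2, `O=C(Nc1cc(Sc2ncn[nH]2)c(O)c2ccccc12)c1ccc(Cl)cc1`: 5520 nM

For the measured compounds named here, compound 2 stands as the only numeric value shown in this assay, with compound 2 giving 5520 nM. Compound 1 gives in this assay only > 100000 nM, which is a limit of the assay and not a number. The two shown values thus sit at the limit of > 100000 nM in this assay, at which 1 of the 2 values shown sits, on one side and a single number on the other.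

Compound 3, `O=C(/C=C/c1ccc(Cl)cc1)Nc1cc(Sc2ncn[nH]2)c(O)c2ccccc12`, is not yet measured. It differs from compound 2 by 2-(4-chlorophenyl)ethenyl in place of 4-chlorophenyl on a carbonyl carbon; in words, 2-(4-chlorophenyl)ethenyl in place of 4-chlorophenyl on a carbonyl carbon. Going by the values given here, no pair of measured compounds shows this change alone, so no measured step sizes it. The only other ethenyl-linked amide in the set, compound 1, reaches only the limit of this assay, and it also carries a different substituent on the ring.

The expected direction for compound 3 is toward weaker inhibition, beyond the scatter, with an estimate of 20000 nM and a range from 4000 nM to 100000 nM. The expected step is a 3.6-fold higher number from compound 2 to compound 3 (0.56 log units; beyond the scatter).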

Compound 3, half-maximal inhibitory concentration: > 100000 nM
Compound 3: a limit, no number; the forecaster's own chance of this, stated with the estimate: 35%; at least 5.0-fold (0.69 log units) between middle value and limit.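

In this assay, for the compounds shown here, 2-(4-chlorophenyl)ethenyl in place of 4-chlorophenyl on a carbonyl carbon gives an at least 18-fold higher number from compound 2 to compound 3 (1.25 log units; beyond the scatter), which is the first measured size for this change, with the chloro substituent held constant. Compound 3 gives > 100000 nM, which is a limit of the assay and not a number, so the true size of the step may be larger. The step for chloro in place of nitro on an aromatic carbon cannot be read, as both of its values are limits, and the two ethenyl-linked amides simply sit together at one limit: the limit of > 100000 nM in this assay, at which 2 of the 3 values shown sit.

Still open, as far as these compounds go, is whether the double bond or the added length of the group on the carbonyl carbon goes with this loss, and the saturated 2-(4-chlorophenyl)ethyl group would separate the two. With compound 2 as the only amide that gives a number, substituent effects on its ring also remain unsized, so a carboxylic acid or a dimethylamino group in place of chloro could show how far this position tolerates change.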